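Changing the group on a carbonyl carbon

The source may report more compounds than this note shows. Statements on the series, on what has been measured and on what is new or still open speak of the compounds shown alone.

Measured in a functional assay on HeLa cells (Homo sapiens) for antiproliferative activity, read by sulforhodamine B assay, with a stated time of 48 h; a lower number here means a stronger inhibitor, a higher number a weaker inhibitor:
- Compound 1 `COc1ccc(C[C@@H](O)/C=C/C=C/C(=O)N2CCCCC2)cc1OC`: 14100 nM
- Compound 2 `COc1ccc(C[C@@H](O)/C=C/C=C/C(=O)NCc2ccc(Cl)cc2)cc1OC`: 13400 nM
- Compound 3 `CCN1CCN(C(=O)/C=C/C=C/[C@H](O)Cc2ccc(OC)c(OC)c2)CC1`: 11700 nM

At 11700 nM, compound 3 stands within the scatter of both other values. Compound 4 `COc1ccc(C[C@@H](O)/C=C/C=C/C(=O)N2CCCC2)cc1OC` differs from it by pyrrolidin-1-yl in place of 4-ethylpiperazin-1-yl on a carbonyl carbon. Three measured swaps at that same place bear on this change: a 1.1-fold lower number from compound 1 to compound 2 (0.02 log units; within the scatter), a 1.2-fold lower number from compound 1 to compound 3 (0.08 log units; within the scatter) and a 1.1-fold lower number from compound 2 to compound 3 (0.06 log units; within the scatter). All three stay within the scatter, so no step beyond the scatter is expected in this assay, in either direction. The expected change is a 1.1-fold higher number from compound 3 to compound 4 (0.05 log units; within the scatter). Compound 4 is estimated at about 13000 nM, with an expected range of 6500 nM to 26000 nM.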

Compound 4, half-maximal inhibitory concentration: 14100 nM
Compound 4: middle estimate off by 1.1-fold (0.04 log units), on the low side; measured number inside the range.
By their numbers in this assay, from the lowest: compounds 3, 2, 1 and 4 (each within the scatter of the next).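

The number in this assay stays level with a fourth group, pyrrolidin-1-yl, on the carbonyl carbon (a 1.2-fold higher number from compound 3 to compound 4 (0.08 log units; within the scatter)), (a 1.1-fold higher number from compound 2 to compound 4 (0.02 log units; within the scatter)) and (no change at the digits printed from compound 1 to compound 4 (within the scatter)). A five-membered ring now sits alongside two six-membered rings and the open (4-chlorobenzyl)amino group, and no swap among these four compounds steps beyond the scatter. Nothing measured here gives a reason for this. Still open, on these data alone, is whether a morpholin-4-yl ring or a chain ending in a carboxylic acid on that carbonyl carbon would step beyond the scatter.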